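The compounds below may be only part of what the source reports. "The series", "measured", "known", "first", "only" and "open" are said of these compounds alone.

In a functional assay on MG-63 cells (Homo sapiens) for inhibition, read by CCK-8 assay, with a stated time of 72 h, tested at 1 uM (on this read-out lower numbers stand for less inhibition and higher numbers for more inhibition at the one concentration tested (going by the name of the read-out)), the three measured compounds gave the following:

Compound 1 `COc1cccc(OC)c1N1C(=O)CSC1c1cccc(C(=O)NCCCCc2ccccc2)c1`: 80%
Compound 2 `CCN1C(=O)CSC1c1cccc(C(=O)NCCCCc2ccccc2)c1`: 0%
Compound 3 `O=C(NCCCCc1ccccc1)c1cccc(C2SCC(=O)N2c2ccccc2)c1`: 89%

Compound 3 has the highest of the three numbers, but one of its gaps is small (a number 9 percentage points higher from compound 1 to compound 3 (within the scatter)), whereas the other is large (a number 89 percentage points higher from compound 2 to compound 3 (beyond the scatter)). Compound 4 `CC(F)(F)c1cccc(N2C(=O)CSC2c2cccc(C(=O)NCCCCc3ccccc3)c2)c1` keeps the whole of compound 3 and differs by 1,1-difluoroethyl in place of hydrogen on an aromatic carbon. The step that bears most directly on this is a number 9 percentage points higher from compound 1 to compound 3 (within the scatter), which shows that changing groups on that ring of the amide-type nitrogen hardly moves the number, while a number 80 percentage points lower from compound 1 to compound 2 (beyond the scatter) shows the large loss only when the ring itself gives way to ethyl. Since compound 4 retains the ring, the expected step is a number 4 percentage points lower from compound 3 to compound 4 (within the scatter), nothing beyond the scatter. Compound 4 is therefore estimated at 85%, between 65% and 97%.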

Compound 4, a percentage reported as inhibition, at one concentration (the size of the read-out at that concentration, not a potency): 92%
For compound 4 the middle estimate is 7 percentage points below the measured one, and the stated range covers the measured number.
By their numbers in this assay, from the lowest: compound 2; then compounds 1, 3 and 4 (each within the scatter of the next, the first and the last beyond it).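

In this assay, the ring on the amide-type nitrogen accepts 1,1-difluoroethyl on an aromatic carbon, meta to a large group, with no real shift (a number 3 percentage points higher from compound 3 to compound 4 (within the scatter)). This substituted ring also stands clear of ethyl (a number 92 percentage points higher from compound 2 to compound 4 (beyond the scatter)) and, modestly, of 2,6-dimethoxyphenyl (a number 12 percentage points higher from compound 1 to compound 4 (beyond the scatter)), a separation that the unsubstituted phenyl ring of compound 3 did not reach. No measurement here explains these steps. As far as these compounds go, whether an amine or a carboxylic acid would be accepted at this position remains open. So does whether 1,1-difluoroethyl would behave alike elsewhere on the ring.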